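The source may hold more compounds than are shown below. What is called first, only, known or untested is meant among the compounds shown, and "the series" means these compounds.

Measured compounds in an ADME assay on Vero cells (Chlorocebus sabaeus) for cytotoxicity, read by resazurin assay, with a stated time of 3 days; a higher number here means a weaker inhibitor, a lower number a stronger inhibitor:
- compound 1 `COc1ccc(C(=O)Nc2cc3nc(C4CCCCC4)[nH]c3cc2N(C)C)cc1`: > 100 ug/mL.
- compound 2 `CN(C)c1cc2[nH]c(C3CCCCC3)nc2cc1NC(=O)OCC(F)(F)F`: > 100 ug/mL.
- compound 3 `CN(C)c1cc2[nH]c(C3CCCCC3)nc2cc1NC(=O)c1ccc(OC(F)F)cc1`: > 100 ug/mL.

For compound 1 the value > 100 ug/mL is a limit of this assay and not a number. For compound 2 the value > 100 ug/mL is likewise a limit. For compound 3 the value > 100 ug/mL is a limit as well. For the measured compounds named here, compound 3 therefore stands at the limit, as the limit of > 100 ug/mL in this assay, at which 3 of the 3 values shown sit, records for every value so far. The steps a step that the two limits leave unreadable from compound 1 to compound 2, a step that the two limits leave unreadable from compound 1 to compound 3 and a step that the two limits leave unreadable from compound 2 to compound 3 all remain unreadable, since two limits bound each of them.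

Compound 4 `CN(C)c1cc2[nH]c(C3CCCCC3)nc2cc1NC(=O)c1cccs1` differs from compound 3 by thiophen-2-yl in place of 4-(difluoromethoxy)phenyl on a carbonyl carbon. The measured steps that touch the same carbonyl substituent, the steps from compound 1 to compound 2 and from compound 2 to compound 3, give no readable size, so no direction beyond the scatter can be drawn from them. The expectation is that compound 4 again reaches the limit; the estimated step that the limit leaves unreadable from compound 3 to compound 4 is thus expected to be small. The estimate for compound 4 is 120 ug/mL, with a range from 50 ug/mL to 300 ug/mL.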

Compound 4, half-maximal inhibitory concentration: > 100 ug/mL
Compound 4: no number, only a limit; the forecaster's own chance of this, stated with the estimate: 80%; the middle value does not contradict the limit.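

In this assay compound 4 gives > 100 ug/mL, a limit and not a number. The steps linking compound 4 with compound 1, compound 2 and compound 3 cannot be read, since two limits bound each one: the limit of > 100 ug/mL in this assay, at which 4 of the 4 values shown sit.

The compounds shown leave open whether the group on the carbonyl carbon changes the read-out at all.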